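The source may report more compounds than this note shows. Statements on the series, on what has been measured and on what is new or still open speak of the compounds shown alone.

Compound 1, `CCCCCCCCNC(=O)[C@@H](NC(=O)/C=C/c1ccccc1)[C@@H](C)O` — in a functional assay on MCF7 cells (Homo sapiens) for cytotoxicity, read by MTT assay, with a stated time of 48 h (on this read-out higher numbers stand for weaker inhibition and lower numbers for stronger inhibition), compound 1 gives 35100 nM.
Compound 2, `C/C=C/C=C/C(=O)N[C@H](C(=O)NCCCCCCCC)[C@@H](C)O` — in this assay compound 2 gives 149000 nM.

For the measured compounds named here, compound 1 holds the lowest number of the two measured; its nearest neighbour is compound 2, and the step of a 4.2-fold higher number from compound 1 to compound 2 (0.63 log units; beyond the scatter) is the only measured comparison in the set.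

Compound 3, `CCCCCCCCCCCCNC(=O)[C@@H](NC(=O)/C=C/c1ccccc1)[C@@H](C)O`, is not yet measured. It differs from compound 1 by butyl in place of hydrogen on a saturated chain carbon, eight bonds along the chain from an amide-type nitrogen; the phenyl-bearing chain of compound 1 is kept as it is.

Going by the values given here, the one measured step concerns a different part of the molecule — the exchange at the double-bonded chain carbon — and therefore does not bear on the change from compound 1 to compound 3. Among the compounds with values here, no measured pair alters the saturated chain at the amide nitrogen. With nothing to go on but the unchanged remainder, the expectation for this assay is a step from compound 1 to compound 3 that stays within the scatter, a 1.2-fold lower number from compound 1 to compound 3 (0.07 log units; within the scatter), direction unknown. Compound 3 is accordingly estimated at 30000 nM, expected within 9000 nM to 100000 nM.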

Compound 3, half-maximal inhibitory concentration: > 200000 nM
Compound 3: no number, only a limit; the forecaster's own chance of this, stated with the estimate: 10%; at least 6.6-fold (0.82 log units) between middle value and limit.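

In this assay, the saturated chain on the amide-type nitrogen proves to be a position that responds, which the earlier pair could not show: butyl in place of hydrogen on a saturated chain carbon, eight bonds along the chain from an amide-type nitrogen, gives an at least 5.6-fold higher number from compound 1 to compound 3 (0.75 log units; beyond the scatter). Compound 3 gives > 200000 nM, which is a limit of the assay and not a number: the limit of > 200000 nM in this assay, at which 1 of the 3 values shown sits. Both changes away from compound 1 now raise the number, the one on the saturated chain and the one at the double-bonded chain carbon, with a 4.2-fold higher number from compound 1 to compound 2 (0.63 log units; beyond the scatter), so compound 1 holds the lowest number in the set at two separate places on the molecule.

Still open, as far as these compounds go, is whether ethyl in the same place would give a number lying between those of compound 1 and compound 3, and whether a shorter chain would lower the number below that of compound 1. Also open, from the compounds shown here alone, are the effect of an amine or a carboxylic acid on this saturated chain and whether the same butyl change on compound 2 would raise its number in the same way.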